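A few compounds are considered here, and "the series" means these few. Any claim that something is new, unique, unknown or untested is made for them only; others in the source may bear on it.

Among the measured compounds shown here, compound 2 `CCCCc1ccc(Cn2ccc3cc(/C(C)=C/C(=O)Nc4ccccc4OCCCC(=O)O)ccc32)cc1` gives 100 nM in an assay on Prostate gland for inhibition of steroid 5-alpha-reductase (Rattus norvegicus) (on this read-out lower numbers stand for stronger inhibition and higher numbers for weaker inhibition), the higher of the two numbers measured so far, while compound 1 `CCCCC(C)n1ccc2cc(/C(C)=C/C(=O)Nc3ccccc3OCCCC(=O)O)ccc21` gives 6 nM in this assay. Compound 3 `CCC(c1ccccc1)n1ccc2cc(/C(C)=C/C(=O)Nc3ccccc3OCCCC(=O)O)ccc21` differs from compound 2 by 1-phenylpropyl in place of 4-butylbenzyl on an aromatic nitrogen. For the measured compounds named here, the only measured step at this nitrogen, a 17-fold higher number from compound 1 to compound 2 (1.22 log units; beyond the scatter), shows that the group there changes the number strongly. The 1-phenylpropyl group is branched at its attachment, as is the 1-methylpentyl group of compound 1, so a partial move back is expected. Compound 3 is therefore expected to give a lower number, a 5.0-fold lower number from compound 2 to compound 3 (0.70 log units; beyond the scatter). Compound 3 is estimated at 20 nM, with a range from 5 nM to 80 nM.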

Compound 3, half-maximal inhibitory concentration: 19 nM
Compound 3: middle estimate off by 1.1-fold (0.02 log units), on the high side, within the range that was stated.
By their numbers in this assay, from the lowest: compound 1; then compound 3; then compound 2.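

The branched 1-phenylpropyl group recovers much of what the 4-butylbenzyl group lost, with a 5.3-fold lower number from compound 2 to compound 3 (0.72 log units; beyond the scatter) at this nitrogen. An aromatic ring on this group is therefore compatible with a low number, yet the change from the 1-methylpentyl group still costs something, with a 3.2-fold higher number from compound 1 to compound 3 (0.50 log units; beyond the scatter) separating the two branched groups. No measurement shown here explains these differences.

The step from compound 2 to compound 3 changes both the branching and the butyl chain, so their shares cannot be separated. As far as these compounds go, how a plain benzyl group or a 1-phenylethyl group would compare remains open.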